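Cytotoxicity notes on the series: compound 2 to compound 4

A few compounds are considered here, and "the series" means these few. Any claim that something is new, unique, unknown or untested is made for them only; others in the source may bear on it.

Measured so far:
compound 1 `N#Cc1ccc(NCc2cncn2Cc2ccc(-c3ccccc3)cc2)cc1-c1ccccc1`: > 1000 nM
compound 2 `COC(=O)c1ccc(NCc2cncn2Cc2cccc(F)c2)cc1-c1ccccc1`: > 1000 nM
compound 3 `Nc1cc(-c2ccccc2)ccc1Cn1cncc1CNc1ccc(-c2cncs2)c(-c2ccccc2)c1`: > 1000 nM

In a toxicity assay on NIH3T3 cells (Mus musculus) for cytotoxicity, read by resazurin assay (a higher number here means that more compound is needed for the effect, a lower number that less compound is needed), compound 1 gives > 1000 nM, which is a limit of the assay and not a number. Compound 2 gives > 1000 nM in this assay, again only a limit. Compound 3 stops at > 1000 nM in this assay, also a limit. Within the data shown here, no pair of measured compounds differs in one place, so no step in this assay can be sized, and compound 2 stands where every value shown stands, at the limit, as the limit of > 1000 nM in this assay, at which 3 of the 3 values shown sit, records.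

Compound 4 `COC(=O)c1ccc(NCc2cncn2Cc2ccccc2[N+](=O)[O-])cc1-c1ccccc1` is compound 2 with 2-nitrophenyl in place of 3-fluorophenyl on a saturated chain carbon bound to an aromatic nitrogen. The step from compound 2 to compound 4 in this assay is expected to be none beyond the scatter, with a step that the limit leaves unreadable from compound 2 to compound 4 as the estimate, because the limit of > 1000 nM in this assay, at which 3 of the 3 values shown sit, is all the series shows. Compound 4 is therefore expected at 2000 nM, within 700 nM to 6000 nM, most likely reported again as a limit.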

Compound 4, half-maximal effective concentration: 10000 nM
The estimate for compound 4 lay 5.0-fold (0.70 log units) below the measured number; measured number outside the range, above it.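

In this assay, among these compounds, compound 2 is recorded only as a limit, so no step from it to compound 4 can be read. The compounds shown leave open whether 2-nitrophenyl in place of 3-fluorophenyl shifts the value at all, and by how much.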